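The source may hold more compounds than are shown below. What is called first, only, known or untested is meant among the compounds shown, and "the series" means these compounds.

Three measured compounds share one core and differ only in the group attached to it. Compound 1 `COc1ccc(-c2cc(C(=O)Nc3ccc(Oc4ccnc5cc(OCCCN6CCCCC6)c(OC)cc45)c(F)c3)c3ccccc3n2)cc1` gives 690 nM in a functional assay on HT-29 cells (Homo sapiens) for cytotoxicity, read by MTT assay, with a stated time of 72 h; on this read-out lower numbers stand for stronger inhibition and higher numbers for weaker inhibition. Compound 2 `COc1cc2c(Oc3ccc(NC(=O)c4cc(-c5ccc(F)cc5)nc5ccccc45)cc3F)ccnc2cc1OCCCN1CCCCC1` gives 130 nM in this assay. Compound 3 `COc1cc2c(Oc3ccc(NC(=O)c4cc(-c5cccc(Cl)c5)nc5ccccc45)cc3F)ccnc2cc1OCCCN1CCCCC1` gives 62 nM in this assay and therefore holds the lowest number of the three. The measured steps all concern the aromatic ring at the far end: a 5.3-fold lower number from compound 1 to compound 2 (0.72 log units; beyond the scatter), an 11-fold lower number from compound 1 to compound 3 (1.05 log units; beyond the scatter) and a 2.1-fold lower number from compound 2 to compound 3 (0.32 log units; beyond the scatter).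

Compound 4 `COc1cc2c(Oc3ccc(NC(=O)c4cc(-c5cccc(Cl)c5)nc5ccccc45)cc3F)ccnc2cc1OCCCN1CCC(C)CC1` is the next case. It differs from compound 3 by methyl in place of hydrogen on a saturated ring carbon. Going by the values given here, no measured step touches this saturated ring; every step on record changes the aromatic substituent and says nothing about the piperidine. Among the compounds with values here, there is thus no measured precedent for this change, and the expectation rests only on its small size. A step within the usual scatter is expected, no change at the digits printed from compound 3 to compound 4 (within the scatter). On that basis compound 4 is estimated at 62 nM in this assay, with a range from 25 nM to 150 nM.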

Compound 4, half-maximal inhibitory concentration: 100 nM
Beside the measured number, compound 4's estimate is 1.6-fold (0.21 log units) below it, and the stated range covers the measured number.
By their numbers in this assay, from the lowest: compounds 3, 4 and 2 (each within the scatter of the next, the first and the last beyond it); then compound 1.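

In this assay the piperidine end of the molecule has its first measured change, and a 1.6-fold higher number from compound 3 to compound 4 (0.21 log units; within the scatter) is a step that stays within the scatter. Going from piperidin-1-yl to 4-methylpiperidin-1-yl, at the ring carbon three ring bonds from the ring nitrogen, therefore gives a number that cannot be told apart from that of the parent, whereas each aromatic substituent change among compound 1, compound 2 and compound 3 gave a step beyond the scatter. Nothing available explains this result.

From the compounds shown here alone, it remains open whether a larger group at this ring carbon, such as phenyl or hydroxyl, or a morpholine in place of the piperidine, would also stay within the scatter. Going by these compounds, it is also open whether the same methyl on compound 1 or compound 2 would give a step of this size.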